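This account rests on a few compounds, and the source may have more. Where it says the series, first, only, none or still open, it means among the compounds named here.

Series notes. Compound 1 `CCCCCOc1nc(N)nc2c1ncn2/C=C1/CC1(CO)CO`, compound 2 `CCCCCCCCSc1nc(N)nc2c1ncn2/C=C1/CC1(CO)CO` and compound 3 `Nc1nc(OCc2ccccc2)c2ncn(/C=C3/CC3(CO)CO)c2n1` share one core and differ only in the group carried on the aromatic carbon. In an ADME assay on Akata cells (Homo sapiens) for cytotoxicity, with a stated time of 7 days (on this read-out lower numbers stand for higher toxicity in this test and higher numbers for lower toxicity in this test), compound 1 gives > 20000 nM, which is a limit of the assay. In this assay compound 2 gives > 20000 nM, again a limit. In this assay compound 3 gives > 20000 nM, also a limit, so compound 3 stands at the limit of > 20000 nM in this assay, at which 3 of the 3 values shown sit. The steps a step that the two limits leave unreadable from compound 1 to compound 2, a step that the two limits leave unreadable from compound 1 to compound 3 and a step that the two limits leave unreadable from compound 2 to compound 3 leave their sizes unreadable. Compound 4 `Nc1nc(SCc2ccccc2)c2ncn(/C=C3/CC3(CO)CO)c2n1` differs from compound 3 by benzylsulfanyl in place of benzyloxy on an aromatic carbon. Within the data shown here, the step from compound 1 to compound 2 is the closest precedent but gives no readable size. Compound 4 is therefore expected to remain at the limit in this assay, estimated at 30000 nM within 15000 nM to 100000 nM. The step that the limit leaves unreadable from compound 3 to compound 4 is expected to stay within the scatter.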

Compound 4, half-maximal cytotoxic concentration: > 20000 nM
Compound 4: no number, only a limit; the forecaster's own chance of this, stated with the estimate: 85%; the middle value does not contradict the limit.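

Compound 4 joins compound 1, compound 2 and compound 3 at a limit in this assay, so no step among these compounds can be read: the limit of > 20000 nM in this assay, at which 4 of the 4 values shown sit.

The compounds shown leave open at what concentration any of them becomes cytotoxic, and whether the group on the aromatic carbon changes that concentration.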